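This account rests on a few compounds, and the source may have more. Where it says the series, first, only, none or still open, it means among the compounds named here.

Measured so far:
- compound 1 `Cc1ccc(C(C)C)c(OCc2nnc(SCC(=O)Nc3ccc(Cl)cc3)n2Cc2ccccc2)c1`: 65.9 ug/mL
- compound 2 `Cc1ccc(C(C)C)c(OCc2nnc(SCC(=O)Nc3ccc(Br)cc3)n2Cc2ccccc2)c1`: 66.7 ug/mL
- compound 3 `CCOC(=O)c1ccc(NC(=O)CSc2nnc(COc3cc(C)ccc3C(C)C)n2Cc2ccccc2)cc1`: 19.8 ug/mL

These three compounds share one core and differ only in the group on the anilide ring. In a toxicity assay on MT4 cells (Homo sapiens) for cytotoxicity, read by MTT assay, with a stated time of 5 days (on this read-out lower numbers stand for higher toxicity in this test and higher numbers for lower toxicity in this test), compound 2 gives the highest of the three numbers. The step of a 1.0-fold higher number from compound 1 to compound 2 (0.01 log units; within the scatter) lies within the scatter, whereas a 3.4-fold lower number from compound 2 to compound 3 (0.53 log units; beyond the scatter) and a 3.3-fold lower number from compound 1 to compound 3 (0.52 log units; beyond the scatter) go beyond it, each a modest drop.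

Compound 4 `O=C(CSc1nnc(COc2ccc3ccccc3c2)n1Cc1ccccc1)Nc1ccc(Br)cc1` has not yet been measured. It differs from compound 2 at another part of the molecule: naphthalen-2-yl in place of 2-isopropyl-5-methylphenyl on an oxygen on a saturated carbon. For the measured compounds named here, none of the measured steps touches this part, so none bears directly on the change; they show only that one halogen for another left the number unchanged, while an ester lowered it modestly. Going by the values given here, with no comparable step to lean on, compound 2 is the only anchor, and a wide range is appropriate. For compound 4 the expected step is a 1.3-fold lower number from compound 2 to compound 4 (0.13 log units; within the scatter). The estimate for compound 4 is 50 ug/mL, with a range from 15 ug/mL to 130 ug/mL.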

Compound 4, half-maximal cytotoxic concentration: 58.1 ug/mL
Compound 4: the middle estimate sits 1.2-fold (0.07 log units) below what was measured; measured number inside the range.
By their numbers in this assay, from the lowest: compound 3; then compounds 4, 1 and 2 (each within the scatter of the next).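

In this assay the exchange of 2-isopropyl-5-methylphenyl for naphthalen-2-yl gives a 1.1-fold lower number from compound 2 to compound 4 (0.06 log units; within the scatter) and so stays within the scatter. For the compounds shown here, the earlier steps changed only the anilide ring, so this is the first sign that the group on the oxygen can change without moving the number beyond the scatter. Both groups hold 10 heavy atoms, all carbon, yet one has a single six-membered aromatic ring and the other has 2, and nothing measured here explains why the number holds.

As far as these compounds go, both groups at this position are made of carbon only, so the effect of a carboxylic acid or an amine on the ring, or of a longer saturated chain in its place, remains open. From the compounds shown here alone, it is also open whether naphthalen-2-yl gives a similar number with ethoxycarbonyl on the anilide ring, the change that lowered the number in compound 3.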